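The compounds below may be only part of what the source reports. "The series", "measured", "known", "first", "only" and "open" are said of these compounds alone.

Compound 1, `Oc1ccccc1CNc1ccc(-c2ccc(F)cc2)cc1`, compound 2, `Oc1ccccc1CNc1ccc(-c2ccc(Cl)cc2)cc1`, and compound 3, `Oc1ccccc1CNc1ccc(-c2ccccc2F)cc1`, share one core and differ in a single group. In a functional assay on Jurkat cells (Homo sapiens) for activation, with a stated time of 24 h (on this read-out lower numbers stand for an effect already at smaller amounts and higher numbers for an effect only at larger amounts of compound), compound 1 gives 3860 nM, compound 2 gives 2390 nM and compound 3 gives 2150 nM; all three sit within the usual scatter of one another, so no order among them can be read. The change chloro in place of fluoro on an aromatic carbon made the step of a 1.6-fold lower number from compound 1 to compound 2 (0.21 log units; within the scatter). Compound 4, `Oc1ccccc1CNc1ccc(-c2ccccc2Cl)cc1`, carries the same kind of change on the core of compound 3: chloro in place of fluoro on an aromatic carbon. The two cores differ as 2-fluorophenyl in place of 4-fluorophenyl on an aromatic carbon, and the place differs as well, being para to a large group in compound 1 but ortho to a large group in compound 3. Because the earlier step of a 1.6-fold lower number from compound 1 to compound 2 (0.21 log units; within the scatter) stayed within the scatter, a step of similar size, a 1.3-fold lower number from compound 3 to compound 4 (0.13 log units; within the scatter), is expected here. Compound 4 is estimated at 1600 nM, between 700 nM and 3600 nM.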

Compound 4, half-maximal effective concentration: "not active" (no number reported)
The entry for compound 4 holds no number; no gap can be computed for the estimate.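

Among these compounds, compound 4 is reported as "not active" without a number in this assay, so no step from compound 3 to compound 4 can be read. The compounds shown leave open how far 2-chlorophenyl in place of 2-fluorophenyl shifts the effect. No evidence shown bears on this result.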